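Aryl variation on a shared amide scaffold and steroid reductase inhibition

The source may hold more compounds than are shown below. What is called first, only, known or untested is meant among the compounds shown, and "the series" means these compounds.

Compound 1 `O=C(O)Cc1ccc(C=C2CCN(C(=O)C(C3CCCCC3)C3CCCCC3)CC2)c(F)c1`: 4%
Compound 2 `O=C(O)c1ccc(OC2CCN(C(=O)N(c3ccccc3)c3ccccc3)CC2)cc1`: 10%
Compound 3 `COc1cc(C(=O)O)ccc1C=C1CCN(C(=O)C(C2CCCCC2)C2CCCCC2)CC1`: 5%

Of the compounds shown here, three have been measured in an assay for inhibition of 3-oxo-5-alpha-steroid 4-dehydrogenase 1 (Homo sapiens), tested at 10 uM; a higher number here means more inhibition at the concentration tested (going by the name of the read-out), a lower number less inhibition. Compound 3 gives 5%, which is the second highest of the three numbers; its nearest neighbour is compound 1, and the furthest is compound 2, both within the scatter of repeated measurements. Among the compounds with values here, the one step between compounds that differ in a single place, a number 1 percentage points higher from compound 1 to compound 3 (within the scatter), is also within the scatter, so the measured set shows no change beyond noise.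

Compound 4 `O=C(O)Cc1ccc(C=C2CCN(C(=O)C(C3CCCCC3)C3CCCCC3)CC2)cc1` is not yet measured. It differs from compound 3 as follows: 4-(carboxymethyl)phenyl in place of 4-carboxy-2-methoxyphenyl on a double-bonded chain carbon bound to a double-bonded ring carbon. The group that enters, 4-(carboxymethyl)phenyl, resembles the 4-(carboxymethyl)-2-fluorophenyl of compound 1 at the same place, and compound 1 gave 4%. Within the data shown here, the only step that bears on this change, a number 1 percentage points higher from compound 1 to compound 3 (within the scatter), was within the scatter. No step beyond the scatter is therefore expected in this assay , and the expected step of no change at the digits printed from compound 3 to compound 4 (within the scatter) is small. Compound 4 is estimated at 5%, with a range from 0% to 15%.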

Compound 4, a percentage reported as inhibition, at one concentration (the size of the read-out at that concentration, not a potency): 6%
For compound 4 the middle estimate is 1 percentage points below the measured one; the measured number falls inside the stated range.
By their numbers in this assay, from the lowest: compounds 1, 3, 4 and 2 (each within the scatter of the next).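

In this assay, the place on a double-bonded chain carbon bound to a double-bonded ring carbon now has a second aryl exchange, and 4-(carboxymethyl)phenyl in place of 4-carboxy-2-methoxyphenyl gives a number 1 percentage points higher from compound 3 to compound 4 (within the scatter). The new compound also provides a comparison that the earlier set lacked, isolating one aromatic substituent: hydrogen in place of fluoro on an aromatic carbon gives a number 2 percentage points higher from compound 1 to compound 4 (within the scatter), so neither this exchange nor the larger aryl exchange moves the read-out beyond the scatter. Nothing available explains why these exchanges leave the read-out within the scatter.

The compounds shown leave open whether any group at this place can move inhibition beyond the scatter, since the aryl groups compared all carry a carboxylic acid, either directly on the ring or through a single carboxymethyl link. An aminomethyl group in place of the carboxymethyl, a longer chain ending in the carboxylic acid, or a chloro in place of the fluoro would test this place further, and their effect in this assay cannot be read from these compounds.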